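This account rests on a few compounds, and the source may have more. Where it says the series, first, only, none or still open, it means among the compounds named here.

Measured so far in a functional assay on SK-BR-3 cells (Homo sapiens) for cytotoxicity, read by MTT assay, with a stated time of 72 h; on this read-out lower numbers stand for an effect already at smaller amounts and higher numbers for an effect only at larger amounts of compound:
Compound 1 `CCOc1c(-c2occ(C)c2CO)ccc2c(CC)cccc12` gives 8.8 ug/mL.
Compound 2 `CCc1cccc2c(OC)c(-c3occ(C)c3COC)ccc12` gives > 10 ug/mL, which is a limit of the assay and not a number.

Compound 2 therefore stands at the limit of > 10 ug/mL in this assay, at which 1 of the 2 values shown sits; of the two measured compounds it is the one for which only a bound, and no value, is known. For the measured compounds named here, compound 1 is the only compound of the pair with a numerical result, and it differs from compound 2 in two places at once, so the two values cannot be read as a single step.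

Compound 3 `CCOc1c(-c2occ(C)c2COC)ccc2c(CC)cccc12` is reached from compound 2 by methyl in place of hydrogen on a saturated chain carbon bound to an oxygen on an aromatic ring, read one bond further out as methoxy to ethoxy. Going by the values given here, no measured pair isolates this change. Among the compounds with values here, the expected step in this assay is small, with no direction beyond the scatter, since a single added methyl on an alkoxy chain has no measured precedent here.

Compound 3 is estimated at 12 ug/mL, in the range 5 ug/mL to 30 ug/mL, an expected step that the limit leaves unreadable from compound 2 to compound 3 that keeps compound 3 near the limit where compound 2 sits.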

Compound 3, concentration for half-maximal effect: > 10 ug/mL
Compound 3: only a limit was reported; the forecaster's own chance of this, stated with the estimate: 55%; the middle value is on the limit's open side.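

In this assay compound 3 gives > 10 ug/mL, a limit of the assay and not a number. Methoxy to ethoxy has no readable size here, as both ends of that change rest on a limit, and the series now gathers at that same limit: the limit of > 10 ug/mL in this assay, at which 2 of the 3 values shown sit.

For the compounds shown here, what is new is the first comparison in one place that has a number at one end: methyl in place of hydrogen on an oxygen on a saturated carbon gives an at least 1.1-fold higher number from compound 1 to compound 3 (0.05 log units; that floor lies within the scatter), which sets only a floor and does not show a real difference between the two compounds.

On these data alone, how far compound 2 and compound 3 lie past the limit stays open, and so does whether methyl on either oxygen moves the read-out at all. A longer chain in place of ethoxy, or an amine in place of the hydroxyl group of compound 1, would show whether either place can bring a value clearly away from the limit.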